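Moving the methoxy group: from compound 3 to compound 4

This account rests on a few compounds, and the source may have more. Where it says the series, first, only, none or still open, it means among the compounds named here.

Measured so far:
Compound 1, `CNC(=O)c1c(O)c2cccnc2n(-c2ccccc2)c1=O`: 9.6%
Compound 2, `COc1ccc(NC(=O)c2c(O)c3cccnc3n(-c3ccccc3)c2=O)cc1`: 0.3%
Compound 3, `Nc1ccc(NC(=O)c2c(O)c3cccnc3n(-c3ccccc3)c2=O)cc1`: -5.5%

In a functional assay on the whole organism for inhibition, with Rattus norvegicus as the target, read by paw edema, at a dose of 100 mg/kg by the oral route (on this read-out lower numbers stand for less inhibition and higher numbers for more inhibition at the one dose given (going by the name of the read-out)), compound 3 has the lowest number of the three. Its nearest neighbour is compound 2, and that gap, a number 5.8 percentage points lower from compound 2 to compound 3 (within the scatter), is within the scatter. Compound 1 is furthest away, and the step of a number 15.1 percentage points lower from compound 1 to compound 3 (beyond the scatter) is beyond the scatter. Compound 2, which also carries a methoxyphenyl group on the amide-type nitrogen, sits near compound 1 through a number 9.3 percentage points lower from compound 1 to compound 2 (within the scatter), within the scatter.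

Compound 4, `COc1cccc(NC(=O)c2c(O)c3cccnc3n(-c3ccccc3)c2=O)c1`, has not yet been measured. The change from compound 3 is 3-methoxyphenyl in place of 4-aminophenyl on an amide-type nitrogen. The closest measured step is the swap of amino for methoxy on an aromatic carbon, a number 5.8 percentage points lower from compound 2 to compound 3 (within the scatter), which lies within the scatter; the new compound carries its methoxy group at a different place on the ring, so it is not the same change. All three measured compounds give small numbers, so compound 4 is expected to stay in that low range, with a step of a number 7.5 percentage points higher from compound 3 to compound 4 (within the scatter) that should not exceed the scatter. The estimate for compound 4 is 2%, from -10% to 14%.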

Compound 4, a percentage reported as inhibition, in the whole organism at one dose (the size of the read-out at that dose, not a potency): 5.7%
Compound 4: the middle estimate sits 3.7 percentage points below what was measured; the measured number falls inside the stated range.
By their numbers in this assay, from the lowest: compounds 3, 2, 4 and 1 (each within the scatter of the next, the first and the last beyond it).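

In this assay, within the data shown here, 3-methoxyphenyl in place of 4-aminophenyl on the amide-type nitrogen gives a number 11.2 percentage points higher from compound 3 to compound 4 (beyond the scatter), the first swap of one substituted phenyl group for another to clear the scatter. Moving the methoxy group, from 4-methoxyphenyl to 3-methoxyphenyl, gives a number 5.4 percentage points higher from compound 2 to compound 4 (within the scatter), so this assay does not separate those two placements. Replacing methyl with 3-methoxyphenyl gives a number 3.9 percentage points lower from compound 1 to compound 4 (within the scatter), which leaves compound 3 as the only one of the three phenyl-bearing compounds whose step from compound 1 is printed as beyond the scatter.

Nothing available explains why these numbers differ. As far as these compounds go, it also remains open how a 3-aminophenyl group would read, which would show whether the amino group or its place on the ring matters more, and how a carboxylic acid on the same ring would compare.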